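A few compounds are considered here, and "the series" means these few. Any claim that something is new, unique, unknown or untested is made for them only; others in the source may bear on it.

Compound 2, `COc1ccccc1C(=O)Nc1ccccc1`, and compound 1, `COc1c(Br)cccc1C(=O)Nc1ccccc1`, share a core; compound 3, `COc1ccccc1C(=O)Nc1ccc(Sc2nc3ccccc3s2)c(Cl)c1`, and the still unmeasured compound 4, `COc1c(Br)cccc1C(=O)Nc1ccc(Sc2nc3ccccc3s2)c(Cl)c1`, share another, and the difference between the two cores is not broken down here. All were tested in an ADME assay on HEK293 cells (Homo sapiens) for cytotoxicity, read by reporter gene assay and resazurin assay, with a stated time of 48 h; a lower number here means that less compound is tolerated, a higher number that more compound is tolerated. In this assay compound 2 gives only a limit, > 100000 nM. Compound 1 likewise gives only a limit, > 100000 nM. Compound 3 too gives only a limit, > 100000 nM, so the limit of > 100000 nM in this assay, at which 3 of the 3 values shown sit, is the whole picture so far. The change from compound 2 to compound 1 is bromo in place of hydrogen on an aromatic carbon and yields a step that the two limits leave unreadable from compound 2 to compound 1. The change from compound 3 to compound 4 is bromo in place of hydrogen on an aromatic carbon; it is the same kind of change, though here the place is meta to a large group rather than meta to a group of 9 heavy atoms. Because the limit of > 100000 nM in this assay, at which 3 of the 3 values shown sit, is all there is, the step from compound 3 to compound 4 is expected to be a step that the limit leaves unreadable from compound 3 to compound 4, read only as a limit. Compound 4 is therefore estimated at 150000 nM, with an expected span from 60000 nM to 500000 nM.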

Compound 4, half-maximal cytotoxic concentration: > 100000 nM
Compound 4 was reported as a limit; the forecaster's own chance of this, stated with the estimate: 85%; the middle value is on the limit's open side.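

Compound 3 and compound 4 each give only a limit in this assay, so no step can be read for bromo in place of hydrogen on an aromatic carbon, and the new result adds no readable comparison: the limit of > 100000 nM in this assay, at which 4 of the 4 values shown sit.

The compounds shown leave open at what concentration any of them harms these cells, and whether bromo alters that concentration at all.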